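The source may hold more compounds than are shown below. What is called first, only, known or untested is meant among the compounds shown, and "the series" means these compounds.

In an ADME assay on MDBK cells (Bos taurus) for cytotoxicity, read by MTT assay, with a stated time of 96 h; a higher number here means that more compound is tolerated, a lower number that less compound is tolerated:
Compound 1 `Clc1cccc(/N=N/N2CCCCC2)c1`: > 100000 nM, a limit
Compound 2 `c1ccc(/N=N/N2CCCCC2)cc1`: > 100000 nM, a limit
Compound 3 `Brc1cccc(/N=N/N2CCCCC2)c1`: > 100000 nM, a limit

Compound 2 has no exact number here, only the limit > 100000 nM. It stands level with the other two compounds, as all three share one ceiling: the limit of > 100000 nM in this assay, at which 3 of the 3 values shown sit.

Compound 4 `Clc1ccc(/N=N/N2CCCCC2)cc1` is compound 2 with chloro in place of hydrogen on an aromatic carbon, para to a group of 8 heavy atoms: chloro in place of hydrogen on an aromatic carbon.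

Among the measured compounds shown here, two measured steps bear on this change: a step that the two limits leave unreadable from compound 1 to compound 2 and a step that the two limits leave unreadable from compound 2 to compound 3. Neither has a readable size, so no step beyond the scatter and no direction can be expected in this assay. The expected step is a number no higher from compound 2 to compound 4 (the limit leaves the size open). For compound 4 the estimated value is 100000 nM, with an expected range of 40000 nM to 200000 nM.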

Compound 4, half-maximal cytotoxic concentration: > 100000 nM
Compound 4: no number, only a limit; the forecaster's own chance of this, stated with the estimate: 80%; the middle value sits exactly at the limit.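

No step from compound 2 to compound 4 can be read, as each carries only a limit and no number: the limit of > 100000 nM in this assay, at which 4 of the 4 values shown sit.

The compounds shown leave open the concentration at which any of them reaches half-maximal cytotoxicity, and whether chloro in place of hydrogen shifts it.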